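The source may report more compounds than this note shows. Statements on the series, on what has been measured and on what is new or still open speak of the compounds shown alone.

Compounds measured in an assay on HEK293 cells for inhibition of Voltage-dependent N-type calcium channel subunit alpha-1B (Homo sapiens), read by fluorescence and calcium flux, with a stated time of 5 min; on this read-out higher numbers stand for weaker inhibition and lower numbers for stronger inhibition:

Compound 1, `COc1ccccc1-n1nc([C@H]2C[C@@H](C)O[C@@H](C)C2)cc1-c1ccc(Cl)cc1`: 3 nM
Compound 2, `COc1ccccc1-n1nc(C2CC(C)(C)OC(C)(C)C2)cc1-c1ccc(Cl)cc1`: 1 nM
Compound 3, `COc1ccccc1-n1nc(C2CC(C)(C)OC(C)(C)C2)cc1-c1ccc(C#N)cc1`: 1 nM

Compound 3 stands level with compound 2 at the digits reported, the two together giving the lowest numbers among the three; the nearest neighbour is compound 2, with no change at the digits reported, and the furthest is compound 1, which gives a higher number. The two steps that join these compounds are of unequal size: a 3.0-fold lower number from compound 1 to compound 2 (0.48 log units; beyond the scatter), whereas no change at the digits printed from compound 2 to compound 3 (within the scatter).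

Compound 4, `CCOc1ccc(-c2cc(C3CC(C)(C)OC(C)(C)C3)nn2-c2ccccc2OC)cn1`, has not yet been measured in this assay. It differs from compound 3 in one place: 6-ethoxypyridin-3-yl in place of 4-cyanophenyl on an aromatic carbon

Among the measured compounds shown here, the step that bears most directly on this change is the one from compound 2 to compound 3, in which the group on the same aromatic carbon was exchanged without any change in the number; the other step, on a different part of the molecule, was modest. For the measured compounds named here, neither step offers a reading on a 6-ethoxypyridin-3-yl group, so the expectation rests on the observation that the one exchange so far at this position left the number unchanged. Compound 4 is therefore expected to give a number close to that of compound 3, with the step of a 2.0-fold higher number from compound 3 to compound 4 (0.30 log units; within the scatter) expected to lie within the scatter or only slightly beyond it. The estimate for compound 4 is 2 nM, with a range from 0.5 nM to 8 nM.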

Compound 4, half-maximal inhibitory concentration: 5 nM
Beside the measured number, compound 4's estimate is 2.5-fold (0.40 log units) below it; measured number inside the range.
By their numbers in this assay, from the lowest: compounds 2 and 3 (each within the scatter of the next); then compounds 1 and 4 (each within the scatter of the next).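

In this assay, the position on the five-membered aromatic ring proves not to be indifferent to what it carries. Whereas cyano in place of chloro on the phenyl group left the number unchanged, 6-ethoxypyridin-3-yl in place of 4-cyanophenyl gives a 5.0-fold higher number from compound 3 to compound 4 (0.70 log units; beyond the scatter), and the same group in place of 4-chlorophenyl gives a 5.0-fold higher number from compound 2 to compound 4 (0.70 log units; beyond the scatter), so both steps are modest but lie beyond the scatter. This single exchange brings in a hetero atom in the six-membered aromatic ring and an ethoxy group while removing the cyano or chloro group, and no measurement available here explains the rise or assigns it to any one of these parts.

As far as these compounds go, it remains open whether the ring hetero atom or the ethoxy group carries the step, a question that 4-ethoxyphenyl and pyridin-3-yl at this position would separate. Also open, from the compounds shown here alone, are what a shorter methoxy or a 6-aminopyridin-3-yl group would give, and whether the step would hold alongside the 2,6-dimethyloxan-4-yl group of compound 1.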